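Benzyl to phenyl on the amide-type nitrogen: a second pair

This account rests on a few compounds, and the source may have more. Where it says the series, first, only, none or still open, it means among the compounds named here.

Measured so far, in a functional assay on HeLa cells (Homo sapiens) for cytotoxicity, read by MTT assay; a higher number here means a weaker inhibitor, a lower number a stronger inhibitor:
compound 1 `CC(C)C[C@H](NC(=S)NCc1ccccc1)c1nc2ccccc2[nH]1`: 31200 nM
compound 2 `CC(C)[C@@H](NC(=S)NCc1ccccc1)c1nc2ccccc2[nH]1`: 12300 nM
compound 3 `CC(C)C[C@H](NC(=S)Nc1ccccc1)c1nc2ccccc2[nH]1`: 29100 nM

Compound 4 `CC(C)[C@@H](NC(=S)Nc1ccccc1)c1nc2ccccc2[nH]1` has not been measured. The difference between the core of compound 1 and the core of compound 2 is not broken down here. Compound 3 is compound 1 with phenyl in place of benzyl on an amide-type nitrogen, and in this assay this gave a 1.1-fold lower number from compound 1 to compound 3 (0.03 log units; within the scatter). Compound 4 is compound 2 with phenyl in place of benzyl on an amide-type nitrogen, the same change at the same place. Compound 2 holds the lowest of the three numbers, beyond the scatter from both compound 1 and compound 3. Because the earlier step read a 1.1-fold lower number from compound 1 to compound 3 (0.03 log units; within the scatter), the step from compound 2 to compound 4 is expected to be a 1.1-fold lower number from compound 2 to compound 4 (0.03 log units; within the scatter). Compound 4 is accordingly estimated at 11500 nM in this assay, with a range from 5500 nM to 24000 nM.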

Compound 4, half-maximal inhibitory concentration: "not active" (no number reported)
Compound 4: no number reported; there is nothing to compare the estimate with.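

Going by these compounds alone, compound 4 is entered as "not active" in this assay without a number, so no step from compound 2 to compound 4 can be read. From the compounds shown here alone, whether benzyl to phenyl on the amide-type nitrogen reads the same on the core of compound 2 as on the core of compound 1 stays open. No evidence bears on this result.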